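A few compounds are considered here, and "the series" means these few. Any claim that something is new, unique, unknown or untested is made for them only; others in the source may bear on it.

Compound 3 `O=C(NC(=S)Nc1ccc(Cl)cc1)c1cn(-c2ccccc2)nc1-c1ccc(F)cc1` is one of three closely related thioureas tested in a functional assay on NCI-H460 cells (Homo sapiens) for inhibition, read by CCK-8 assay, with a stated time of 48 h (a higher number here means a weaker inhibitor, a lower number a stronger inhibitor), where compound 3 gives 3090 nM. Compound 1 `COc1ccc(-c2nn(-c3ccccc3)cc2C(=O)NC(=S)Nc2ccc(F)cc2)cc1` gives 3050 nM and compound 2 `O=C(NC(=S)Nc1ccc(Cl)cc1)c1cn(-c2ccccc2)nc1-c1ccc(Cl)cc1` gives 3260 nM; all three numbers sit within the usual scatter of one another, so none of them can be called weaker or stronger than the rest. Among the compounds with values here, the only one-point comparison among them is a 1.1-fold lower number from compound 2 to compound 3 (0.02 log units; within the scatter), a change that falls on the same aromatic carbon that is altered next.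

Compound 4 `COc1ccc(-c2nn(-c3ccccc3)cc2C(=O)NC(=S)Nc2ccc(Cl)cc2)cc1` has not been measured. It differs from compound 3 by methoxy in place of fluoro on an aromatic carbon. Two observations bear on this. First, exchanging one halogen for another there, from compound 2 to compound 3, left the number essentially where it was. Second, compound 1, which carries the methoxy group instead of the fluoro, gives a value indistinguishable from that of compound 3, although compound 1 also differs from compound 3 on the other aromatic ring. Neither point suggests a move beyond the scatter, so compound 4 is expected to shift only by a 1.0-fold higher number from compound 3 to compound 4 (0.00 log units; within the scatter). The estimate for compound 4 in this assay is 3100 nM, with a range from 1500 nM to 6500 nM.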

Compound 4, half-maximal inhibitory concentration: 3010 nM
Compound 4: the middle estimate sits 1.0-fold (0.01 log units) above what was measured; low and high end bracket the measured number.
By their numbers in this assay, from the lowest: compounds 4, 1, 3 and 2 (each within the scatter of the next).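

Within the data shown here, until now, the methoxy group could be seen only in compound 1, which also differs from compound 3 on the other aromatic ring, so its effect at this position could not be read alone. In this assay, the 4-fluorophenyl to 4-methoxyphenyl change can now be read by itself, as a 1.0-fold lower number from compound 3 to compound 4 (0.01 log units; within the scatter), and methoxy can also be set against chloro at the same place, as a 1.1-fold lower number from compound 2 to compound 4 (0.03 log units; within the scatter). The step of a 1.0-fold lower number from compound 1 to compound 4 (0.01 log units; within the scatter) adds a second reading of the exchange between the two halogens on the other aromatic ring, and the two readings of that exchange agree: the same change on two cores in this assay, a 1.1-fold lower number (0.02 log units; within the scatter) from compound 2 to compound 3 and a 1.0-fold higher number (0.01 log units; within the scatter) from compound 4 to compound 1, 1.1-fold (0.03 log units) apart, within the scatter of two such steps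

Among compounds 2, 3 and 4, fluoro, chloro and methoxy at this position all fall within the scatter of one another, but these three groups say nothing about how an amine, a carboxylic acid or a longer chain such as butoxy would behave there. Going by these compounds, it also remains open whether this flat picture would hold on cells other than NCI-H460, or if a urea took the place of the thiourea.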